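The source may hold more compounds than are shown below. What is called first, only, known or untested is meant among the compounds shown, and "the series" means these compounds.

Compound 1 `CCC(C)Nc1cc(Oc2c(OC)cc3cc(C#N)ccc3c2OC)nc(Nc2ccc(C#N)cc2)n1`. In an ADME assay on MT4 cells (Homo sapiens) for cytotoxicity, read by MTT assay, with a stated time of 5 days (on this read-out lower numbers stand for higher toxicity in this test and higher numbers for lower toxicity in this test), compound 1 gives > 125000 nM, which is a limit of the assay and not a number.
Compound 2 `CCC(CC)Nc1cc(Oc2c(OC)cc3cc(C#N)ccc3c2OC)nc(Nc2ccc(C#N)cc2)n1`. In this assay compound 2 gives > 125000 nM, again a limit of the assay.
Compound 3 `COc1cc2cc(C#N)ccc2c(OC)c1Oc1cc(NCCCOC(C)C)nc(Nc2ccc(C#N)cc2)n1`. In this assay compound 3 gives > 125000 nM, once more a limit.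

Compound 1 therefore stands at the limit of this assay, and it shares that position with every other measured compound: the limit of > 125000 nM in this assay, at which 3 of the 3 values shown sit. None of the steps among them can be read. The step that the two limits leave unreadable from compound 1 to compound 2, the step that the two limits leave unreadable from compound 1 to compound 3 and the step that the two limits leave unreadable from compound 2 to compound 3 are all left unreadable by the two limits.

Compound 4 `COc1cc2cc(C#N)ccc2c(OC)c1Oc1cc(NCC(O)CO)nc(Nc2ccc(C#N)cc2)n1` differs from compound 1 in one place: 2,3-dihydroxypropyl in place of sec-butyl on a nitrogen on an aromatic ring. The measured steps that bear on this change are those ending at compound 3, where sec-butyl or pentan-3-yl gives way to 3-isopropoxypropyl on the same nitrogen; both were unreadable, so no step beyond the scatter can be expected in this assay in either direction. Compound 4 is expected to remain at the limit, an estimated step of a number no higher from compound 1 to compound 4 (the limit leaves the size open). Compound 4 is thus estimated at 125000 nM, within 60000 nM to 125000 nM.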

Compound 4, half-maximal cytotoxic concentration: 29500 nM
The estimate for compound 4 lay 4.2-fold (0.63 log units) above the measured number; measured number below the stated range.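

On the nitrogen on an aromatic ring, 2,3-dihydroxypropyl is the only group shown that gives a readable change in this assay: in place of sec-butyl it gives an at least 4.2-fold lower number from compound 1 to compound 4 (0.62 log units; beyond the scatter) and in place of pentan-3-yl it gives an at least 4.2-fold lower number from compound 2 to compound 4 (0.62 log units; beyond the scatter) on that nitrogen, while 1,2-dihydroxyethyl in place of 2-isopropoxyethyl on the saturated chain carbon bound to that nitrogen gives an at least 4.2-fold lower number from compound 3 to compound 4 (0.62 log units; beyond the scatter) in the same test. The steps among compounds 1, 2 and 3 cannot be read, so this position had shown no response until compound 4 moved towards higher toxicity in this test. Compound 4 alone carries a number and not a limit: the limit of > 125000 nM in this assay, at which 3 of the 4 values shown sit.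

Going by these compounds, how far each of these steps truly reaches stays open. Also open, on these data alone, is whether a chain with a single hydroxyl, an amine or a carboxylic acid on the same nitrogen would move the read-out as 2,3-dihydroxypropyl does.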